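From Isopropyl to Cyclohexyl on the Amide Nitrogen

The compounds below may be only part of what the source reports. "The series", "measured", "known", "first", "only" and "open" are said of these compounds alone.

In a functional assay on the whole organism with Mus musculus as the target (on this read-out lower numbers stand for an effect already at smaller amounts and higher numbers for an effect only at larger amounts of compound), compound 1 `CN1C(=O)CCC1(O)c1cccc(C(F)(F)F)c1` gives 93.8 mg/kg. Compound 2 `CCN1C(=O)CCC1(O)c1cccc(C(F)(F)F)c1` reads > 100 mg/kg, which is a limit and not a number. Compound 3 `CC(C)NC(=O)CCC(=O)c1cccc(C(F)(F)F)c1` reads > 200 mg/kg, which is also a limit. Compound 4 `O=C(CCC(=O)c1cccc(C(F)(F)F)c1)NC1CCCCC1` carries cyclohexyl in place of isopropyl on an amide-type nitrogen. Within the data shown here, the one measured step that bears on this change is an at least 1.0-fold higher number from compound 1 to compound 2 (0.02 log units; that floor lies within the scatter). It also enlarges a group on a nitrogen, though on a different core. No change beyond the scatter is therefore expected in this assay, and no direction can be favoured. The expected step is a step that the limit leaves unreadable from compound 3 to compound 4. For compound 4 the estimated value is 220 mg/kg, with an expected range of 90 mg/kg to 500 mg/kg.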

Compound 4, dose for half-maximal effect: > 200 mg/kg
Compound 4: no number, only a limit (the forecaster's own chance of this, stated with the estimate: 70%); the middle value is on the limit's open side.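

Among these compounds, compound 3 and compound 4 each give only a limit, not a number, so no step between them can be read. Going by these compounds, whether cyclohexyl in place of isopropyl changes the effective dose remains open.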